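Adding a methyl to the ring amine of compound 3

A few compounds are considered here, and "the series" means these few. Any claim that something is new, unique, unknown or untested is made for them only; others in the source may bear on it.

Compound 3 `Brc1cncc(OC[C@@H]2C[C@H]3C[C@H]3N2)c1` gives 6.4 nM in an assay on CHO-K1 cells for displacement of a labelled ligand from Neuronal acetylcholine receptor; alpha4/beta2 (Homo sapiens), read by scintillation counting (a lower number here means a stronger inhibitor, a higher number a weaker inhibitor), the highest of the three numbers in hand. Its closest neighbour is compound 2 `CN1[C@H](COc2cccnc2)C[C@H]2C[C@H]21`, which in this assay gives 5.5 nM, a gap within the scatter. Compound 1 `CN1[C@H](COc2cncc(Cl)c2)C[C@H]2C[C@H]21` gives 0.37 nM in this assay and stands furthest from compound 3. Among the compounds with values here, the only single-change step measured is a 15-fold higher number from compound 1 to compound 2 (1.17 log units; beyond the scatter), which concerns a halogen on the aromatic ring and not the ring amine. Compound 4 `CN1[C@H](COc2cncc(Br)c2)C[C@H]2C[C@H]21` differs from compound 3 by methyl in place of hydrogen on an amine nitrogen in a ring. Within the data shown here, no measured pair isolates this change; compound 1 and compound 3 differ at the halogen as well as at the amine, so their values alone do not settle how much the methyl contributes. Since compound 1, which carries the methyl with a halogen on the ring, gives 0.37 nM, compound 4 is expected to fall toward a lower number, a step of a 6.4-fold lower number from compound 3 to compound 4 (0.81 log units; beyond the scatter) being the estimate. For compound 4 the expected value in this assay is 1 nM, with a likely range from 0.2 nM to 5 nM.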

Compound 4, inhibition constant: 4.2 nM
Beside the measured number, compound 4's estimate is 4.2-fold (0.62 log units) below it; low and high end bracket the measured number.
By their numbers in this assay, from the lowest: compound 1; then compounds 4, 2 and 3 (each within the scatter of the next).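

With bromo on the aromatic ring, methyl in place of hydrogen on the amine nitrogen in the ring gives a step that lies within the scatter in this assay (a 1.5-fold lower number from compound 3 to compound 4 (0.18 log units; within the scatter)). At the aromatic carbon, bromo in place of hydrogen also stays within the scatter (a 1.3-fold lower number from compound 2 to compound 4 (0.12 log units; within the scatter)). Bromo in place of chloro, however, gives a large step (an 11-fold higher number from compound 1 to compound 4 (1.06 log units; beyond the scatter)), so among the methylated compounds, compound 1 with its chloro stands apart from both compound 2 and compound 4.

Within the data shown here, whether the methyl counts for as little when chloro sits on the aromatic carbon stays open, since no pair shows that change with chloro present. Also open, as far as these compounds go, is what an ethyl on the amine nitrogen or a fluoro on the aromatic carbon would give. No supporting data are available to explain these results.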